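Piperidin-4-yl Replaces Cyclohexylmethyl on a Terminal Amine

The source may hold more compounds than are shown below. What is called first, only, known or untested is meant among the compounds shown, and "the series" means these compounds.

Compound 1 `c1ccc(CN(CCCCN(C[C@H]2Cc3ccccc3CN2)[C@H]2CCCc3cccnc32)Cc2ccccn2)nc1` gives only a limit, > 30000 nM, in a functional assay on cells for agonist activity at C-X-C chemokine receptor type 4 (Homo sapiens), read by fluorescence and calcium flux, with a stated time of 90 s; a lower number here means that less compound is needed, a higher number that more compound is needed for the effect.
Compound 2 `c1cncc(CN(CCCCN(C[C@H]2Cc3ccccc3CN2)[C@H]2CCCc3cccnc32)Cc2cccnc2)c1` likewise gives only a limit, > 30000 nM.
Compound 3 `c1ccc2c(c1)CN[C@@H](CN(CCCCNCC1CCCCC1)[C@H]1CCCc3cccnc31)C2` also gives only a limit, > 30000 nM.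

Compound 3 therefore stands nowhere definite on the numbers shown: its value is a limit, not a measured number, and the same is true of the two other values, since (the limit of > 30000 nM in this assay, at which 3 of the 3 values shown sit). Among the compounds with values here, no pair of measured compounds differing in a single place is available, so no measured step can be quoted, and nothing about the size of any change can be read from these three.

Compound 4 `c1ccc2c(c1)CN[C@@H](CN(CCCCNC1CCNCC1)[C@H]1CCCc3cccnc31)C2` differs from compound 3 in one place: piperidin-4-yl in place of cyclohexylmethyl on an amine nitrogen. With every measured compound sitting at the limit of this assay, there is no ground to expect a step in either direction beyond the usual scatter, and the most likely outcome is that compound 4 also returns a limit. The step from compound 3 to compound 4 is accordingly expected to be a number no higher from compound 3 to compound 4 (the limit leaves the size open). For compound 4 the estimate in this assay is 30000 nM, with a range from 5000 nM to 100000 nM.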

Compound 4, half-maximal effective concentration: > 30000 nM
Compound 4: only a limit was reported; the forecaster's own chance of this, stated with the estimate: 75%; the middle value sits exactly at the limit.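

In this assay compound 4 gives > 30000 nM as a limit and not a number. Within the data shown here, no step from compound 3 to compound 4 can be read, since both values are limits: the limit of > 30000 nM in this assay, at which 4 of the 4 values shown sit. The compounds shown leave open whether piperidin-4-yl in place of cyclohexylmethyl on this amine nitrogen changes the concentration needed for the effect, and in which direction.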